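A few compounds are considered here, and "the series" means these few. Any claim that something is new, unique, unknown or untested is made for them only; others in the source may bear on it.

Three compounds in a shared series have been examined in an ADME assay on HepG2 cells (Homo sapiens) for cytotoxicity, read by luminescence, CellTiter-Glo and ATP content, with a stated time of 72 h; a higher number here means that more compound is needed for the effect, a lower number that less compound is needed. Compound 1 `COc1ccc(-c2ccc3c(NCCCNCc4cccc(OC)c4O)ccnc3c2)cc1` gives 1600 nM. Compound 2 `COc1cccc(Oc2ccc3c(NCCCNCc4cc(F)ccc4OC)ccnc3c2)c1` gives 7100 nM. Compound 3 `COc1cccc(CNCCCNc2ccnc3cc(Cc4cc(C)cc(C)c4)ccc23)c1O` gives 2680 nM. Among these numbers compound 3 stands second highest: its nearest neighbour is compound 1, and the single step that connects them, a 1.7-fold higher number from compound 1 to compound 3 (0.22 log units; within the scatter), lies within the scatter, so the two cannot be told apart on this evidence; compound 2 stands furthest away with a higher number beyond the scatter.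

The next compound, compound 4 `COc1cccc(Oc2ccc3c(NCCCNCc4cccc(OC)c4O)ccnc3c2)c1`, follows from compound 3 by one exchange: 3-methoxyphenoxy in place of 3,5-dimethylbenzyl on an aromatic carbon. Among the compounds with values here, no measured step covers this exchange directly. Within the data shown here, the only step available, from compound 1 to compound 3, changed the same position without moving the number beyond the scatter. Compound 2 carries the same 3-methoxyphenoxy group that enters here, but it also differs from compound 4 elsewhere, so its value is only a loose pointer toward somewhat higher numbers. On that basis the step of a 1.5-fold higher number from compound 3 to compound 4 (0.17 log units; within the scatter) is expected to be modest and directed upward, if it leaves the scatter at all. For compound 4 in this assay the estimate is 4000 nM, with a range from 1500 nM to 11000 nM.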

Compound 4, half-maximal effective concentration: 5300 nM
The estimate for compound 4 lay 1.3-fold (0.12 log units) below the measured number, within the range that was stated.
By their numbers in this assay, from the lowest: compounds 1, 3, 4 and 2 (each within the scatter of the next, the first and the last beyond it).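

In this assay, within the data shown here, the exchange at this aromatic carbon gives a 2.0-fold higher number from compound 3 to compound 4 (0.30 log units; within the scatter) and so stays within the scatter, whereas 3-methoxyphenoxy in place of 4-methoxyphenyl gives a 3.3-fold higher number from compound 1 to compound 4 (0.52 log units; beyond the scatter) and is the first step at this position to leave it, though only modestly. The group on this carbon can therefore move the number, but the 3-methoxyphenoxy and 3,5-dimethylbenzyl groups cannot be told apart here. The change on the saturated chain carbon bound to an amine nitrogen gives its first reading as a 1.3-fold lower number from compound 2 to compound 4 (0.13 log units; within the scatter) and also stays within the scatter, so with 3-methoxyphenoxy on the core, 2-hydroxy-3-methoxyphenyl and 5-fluoro-2-methoxyphenyl cannot be separated, and nothing at hand offers an explanation for any of these steps.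

The compounds shown leave open whether a carboxylic acid or a morpholine on the aromatic carbon would carry the number further from these values. On these data alone, they also rest the saturated chain carbon on a single pair, so it remains open whether an unsubstituted phenyl there would give a step beyond the scatter.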